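From a Dichlorophenyl to a Dimethoxyphenyl Ring

This account rests on a few compounds, and the source may have more. Where it says the series, first, only, none or still open, it means among the compounds named here.

Of the compounds shown here, two sharing one core have been measured so far. Compound 1 `COc1cc(-c2cc(/C=C/C(=O)c3ccc(N)cc3)[nH]n2)cc(OC)c1OC` carries a 4-aminophenyl group on the carbonyl carbon, and compound 2 `COc1cc(-c2cc(/C=C/C(=O)c3ccc(Cl)c(Cl)c3)[nH]n2)cc(OC)c1OC` carries a 3,4-dichlorophenyl group there instead. In a functional assay on MOLT-4 cells (Homo sapiens) for cytotoxicity, read by sulforhodamine B assay, with a stated time of 48 h, tested at 100 uM (on this read-out higher numbers stand for a weaker effect at the one concentration tested and lower numbers for a stronger effect), compound 1 gives -20%, and compound 2 gives -15%. For the measured compounds named here, the only step known, a number 5 percentage points higher from compound 1 to compound 2 (within the scatter), is within the scatter, so the two compounds cannot be ordered; compound 2 simply has the higher of the two numbers, with compound 1 the nearest.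

Compound 3 `COc1ccc(C(=O)/C=C/c2cc(-c3cc(OC)c(OC)c(OC)c3)n[nH]2)cc1OC` is not yet measured. It differs from compound 2 in one place: 3,4-dimethoxyphenyl in place of 3,4-dichlorophenyl on a carbonyl carbon. Going by the values given here, the single step that bears on this change, the swap at the same carbonyl carbon from compound 1 to compound 2, stayed within the scatter. On that basis no step beyond the scatter is expected in this assay for the change from compound 2 to compound 3, in either direction; the expected step is a number 5 percentage points higher from compound 2 to compound 3 (within the scatter). Compound 3 is therefore estimated at -10%, with a range from -40% to 20%.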

Compound 3, a percentage reported as activity, at one concentration (the size of the read-out at that concentration, not a potency): -23%
Estimate against measurement, compound 3: 13 percentage points above, within the range that was stated.
By their numbers in this assay, from the lowest: compounds 3, 1 and 2 (each within the scatter of the next).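

On the carbonyl carbon, 3,4-dimethoxyphenyl in place of 3,4-dichlorophenyl gives a number 8 percentage points lower from compound 2 to compound 3 (within the scatter) in this assay and, in place of 4-aminophenyl, gives a number 3 percentage points lower from compound 1 to compound 3 (within the scatter) on the same read-out. For the compounds shown here, the earlier pair offered only one swap at this place; there are now three groups there, and all three pairs lie within the scatter of one another. At the one concentration tested, this read-out does not separate these three rings, and the two hydrogen-bond acceptors that enter with 3,4-dimethoxyphenyl bring no step beyond the scatter.

Going by these compounds, whether a quite different group on this carbonyl carbon, such as a plain methyl or a phenyl ring bearing a carboxylic acid, would give a step beyond the scatter stays open. No evidence at hand explains why the three numbers lie so close.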